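One Flipped Stereocentre in Compound 1

The compounds below may be only part of what the source reports. "The series", "measured", "known", "first", "only" and "open" are said of these compounds alone.

Among the measured compounds shown here, in a functional assay on A549 cells (Homo sapiens) for cytotoxicity, read by MTT assay, with a stated time of 48 h (a lower number here means a stronger inhibitor, a higher number a weaker inhibitor), compound 1 `CCOC(=O)[C@]1(C(=O)Nc2ccccc2)C[C@H]1c1cc(OC)c(OC)c(OC)c1` gives 37300 nM, the highest number of the three measured so far, which makes it the weakest inhibitor among them. Compound 2 `CCOC(=O)[C@]1(C(=O)NCc2ccc(C)cc2)C[C@H]1c1cc(OC)c(OC)c(OC)c1` gives 13300 nM, and compound 3 `CCOC(=O)[C@]1(C(=O)Nc2ccccc2Cl)C[C@H]1c1cc(OC)c(OC)c(OC)c1` gives 13400 nM. Compound 4 `CCOC(=O)[C@@]1(C(=O)Nc2ccccc2)C[C@H]1c1cc(OC)c(OC)c(OC)c1` is next, and its change from compound 1 is subtle: the two compounds have the same atoms and bonds and differ only in configuration as drawn: 1 of 2 stereo elements differ; a stereocentre at a saturated ring carbon is drawn R in compound 1 and S in compound 4. Nothing enters or leaves, so only the arrangement in space differs.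

For the measured compounds named here, none of the measured steps alters configuration, so they offer only indirect guidance. Putting 4-methylbenzyl in place of phenyl on the amide-type nitrogen gave a 2.8-fold lower number from compound 1 to compound 2 (0.45 log units; beyond the scatter), and putting chloro in place of hydrogen on an aromatic carbon gave a 2.8-fold lower number from compound 1 to compound 3 (0.44 log units; beyond the scatter). The remaining comparison shows a 1.0-fold higher number from compound 2 to compound 3 (0.00 log units; within the scatter). These steps are modest at most, but they all involve the group on the amide-type nitrogen, not a stereocentre, and so they give no direction for this change. With no evidence favouring either direction, the estimate stays close to the value of compound 1, and the expected change is a 1.2-fold lower number from compound 1 to compound 4 (0.09 log units; within the scatter). A modest move either way would still not be surprising. Compound 4 is estimated at 30000 nM, with an expected range from 12000 nM to 75000 nM.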

Compound 4, half-maximal inhibitory concentration: 65900 nM
The estimate for compound 4 lay 2.2-fold (0.34 log units) below the measured number, within the range that was stated.
By their numbers in this assay, from the lowest: compounds 2 and 3 (each within the scatter of the next); then compounds 1 and 4 (each within the scatter of the next).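

In this assay, among the compounds shown here, the first change at this stereocentre rather than on the amide-type nitrogen gives a 1.8-fold higher number from compound 1 to compound 4 (0.25 log units; within the scatter), so drawing the saturated ring carbon as S instead of R leaves a gap no larger than repeat measurements of this kind can produce. With phenyl on the amide-type nitrogen, these numbers therefore give no ground for preferring either drawn form at this position, even though the earlier changes to that nitrogen group went beyond the scatter. The comparison is also unusually clean, since any real gap here could come only from the arrangement in space, because nothing else separates the pair: the fact that compounds 1 and 4 differ only in the configuration as drawn.

From the compounds shown here alone, it remains open whether flipping this stereocentre would also give so small a step with 4-methylbenzyl or 2-chlorophenyl on the amide-type nitrogen, and what the second stereocentre contributes when it is the one inverted. The compounds shown also leave open how the numbers would respond to a carboxylic acid in place of the ester, or to an amine on the aromatic ring of the amide group.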